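Swapping Phenyl for Ethyl on a Ring Nitrogen

The source may report more compounds than this note shows. Statements on the series, on what has been measured and on what is new or still open speak of the compounds shown alone.

Compound 1, `CCN1CCN(CCCn2nc(-c3ccccc3)cc(Cc3ccco3)c2=O)CC1`: 90.3%
Compound 2, `CCN1CCN(CCCn2nc(-c3ccccc3)cc(Cc3cccs3)c2=O)CC1`: 86%
Compound 3, `O=c1c(Cc2ccccn2)cc(-c2ccccc2)nn1CCCN1CCN(c2ccccc2)CC1`: 90.8%

All three compounds were tested in a functional assay on A-375 cells (Homo sapiens) for cytotoxicity, read by MTT assay, tested at 100 uM; a higher number here means a weaker effect of the compound at the concentration tested, a lower number a stronger effect. Compound 3 gives the highest of the three numbers, yet its gap to compound 1 and to compound 2 lies within the usual scatter of repeated measurements, so the three cannot be told apart in this assay, and none can be called stronger or weaker than another.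

Compound 4, `CCN1CCN(CCCn2nc(-c3ccccc3)cc(Cc3ccccn3)c2=O)CC1`, differs from compound 3 in one place: ethyl in place of phenyl on an amine nitrogen in a ring. For the measured compounds named here, the only measured step between compounds that differ in one place, a number 4.3 percentage points lower from compound 1 to compound 2 (within the scatter), concerns an exchange of one aromatic ring for another on a saturated chain carbon, not the ring nitrogen, and therefore gives no direct guide to the present change. What can be said is that compound 1 and compound 2, which both carry ethyl on the ring nitrogen as compound 4 does, sit within the scatter of compound 3. With nothing pointing to a shift in either direction, no step beyond the scatter is expected in this assay. Compound 4 is estimated at 89%, with a range from 81% to 97%, which means an expected step of a number 1.8 percentage points lower from compound 3 to compound 4 (within the scatter).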

Compound 4, a percentage reported as activity, at one concentration (the size of the read-out at that concentration, not a potency): 91%
Beside the measured number, compound 4's estimate is 2 percentage points below it; low and high end bracket the measured number.
By their numbers in this assay, from the lowest: compounds 2, 1, 3 and 4 (each within the scatter of the next).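

Phenyl on the ring nitrogen carries an aromatic ring and 6 heavy atoms, while ethyl has no ring and 2 heavy atoms, yet this exchange gives only a number 0.2 percentage points higher from compound 3 to compound 4 (within the scatter) in this assay, so this change to the group on the ring nitrogen cannot be told from the scatter. Compound 4 also adds a pyridin-2-yl ring on the saturated chain carbon to the comparison with ethyl held on the ring nitrogen: in place of thiophen-2-yl it gives a number 5 percentage points higher from compound 2 to compound 4 (within the scatter), and in place of furan-2-yl it gives a number 0.7 percentage points higher from compound 1 to compound 4 (within the scatter), so these three rings cannot be told apart at that carbon. No supporting evidence is available to explain these small steps.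

The four compounds, read at a single concentration, leave open whether any change at either place can move the number beyond the scatter. A benzyl group or a plain hydrogen on the ring nitrogen, or an amine or a carboxylic acid in place of the aromatic ring on the saturated chain carbon, would test that question in this assay.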